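The source may report more compounds than this note shows. Statements on the series, on what has been measured and on what is new or still open speak of the compounds shown alone.

Measured so far:
compound 1 `COc1ccc2nc(C)cc(OCC(=O)Nc3ccc4c(c3)CCC4)c2c1`, 0.195 h
compound 2 `COc1ccc2nc(C)cc(OCC(=O)Nc3ccc(C)cc3)c2c1`, 0.423 h

Going by the values given here, compound 1 stands lowest of the two numbers in an ADME assay on liver (Homo sapiens) for metabolic stability, read by LC-MS, using S9 fraction, tested at 2 uM; on this read-out lower numbers stand for a shorter-lived compound and higher numbers for a longer-lived compound; the only measured step, a 2.2-fold higher number from compound 1 to compound 2 (0.34 log units; beyond the scatter), goes upward. Compound 3 `COc1ccc2nc(C)cc(OCC(=O)Nc3ccc(C)c(C)c3)c2c1` differs from compound 1 by 3,4-dimethylphenyl in place of 2,3-dihydro-1H-inden-5-yl on an amide-type nitrogen. Among the compounds with values here, that step bears on the one from compound 1 to compound 2, since a methyl-bearing phenyl again replaces the fused ring, so a similar modest rise, or at most one near the scatter, is expected: a 1.5-fold higher number from compound 1 to compound 3 (0.19 log units; within the scatter). Compound 3 is therefore estimated at 0.3 h, within 0.15 h to 0.6 h.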

Compound 3, half-life in the liver assay: 0.237 h
Beside the measured number, compound 3's estimate is 1.3-fold (0.10 log units) above it; measured number inside the range.
By their numbers in the liver assay, from the lowest: compounds 1, 3 and 2 (each within the scatter of the next, the first and the last beyond it).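

In the liver assay, the 3,4-dimethylphenyl group cannot be told apart from the fused ring of compound 1 (a 1.2-fold higher number from compound 1 to compound 3 (0.08 log units; within the scatter)), and the added methyl on an aromatic carbon gives no readable shift either (a 1.8-fold lower number from compound 2 to compound 3 (0.25 log units; within the scatter)). The same replacement does separate in a physicochemical assay for permeability, using PAMPA, with a stated time of 5 min, tested at 1 uM (on this read-out lower numbers stand for lower permeability and higher numbers for higher permeability), where compound 1 gives (13.1 10^-6 cm/s) and compound 3 gives (5.9 10^-6 cm/s), a step beyond the scatter (a 2.2-fold lower number from compound 1 to compound 3 (0.35 log units; beyond the scatter)). So at this place on the amide-type nitrogen, the two read-outs need not follow each other. From the compounds shown here alone, whether an amine or a carboxylic acid on the phenyl ring would shift the half-life beyond the scatter remains open.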